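Chain extension on the fluoroindole amine series

This account rests on a few compounds, and the source may have more. Where it says the series, first, only, none or still open, it means among the compounds named here.

Measured so far:
compound 1, `CNCCCc1c[nH]c2ccc(F)cc12`, 26 nM
compound 2, `CN1CCN(CCCc2c[nH]c3ccc(F)cc23)CC1`, 310 nM

In an assay on isolated protein for inhibition of Myeloperoxidase (Homo sapiens) (on this read-out higher numbers stand for weaker inhibition and lower numbers for stronger inhibition), compound 1 gives 26 nM, the lowest of the two numbers recorded. Compound 2 gives 310 nM in this assay, a higher number that lies beyond the usual scatter. Within the data shown here, no pair differing in a single place has yet been measured, so no step size is established.

Compound 3, `NCCCCCCc1c[nH]c2ccc(F)cc12`, is not yet measured. It differs from compound 1 by 3-aminopropyl in place of methylamino on a saturated chain carbon, three bonds along the chain from an aromatic carbon. The change keeps the donor and acceptor count of the group but lengthens the chain. Among the measured compounds shown here, with the two numbers from compound 1 and compound 2 as the only guide, a small step toward a higher number is expected, near the edge of the scatter rather than clearly beyond it: a 1.9-fold higher number from compound 1 to compound 3 (0.28 log units; within the scatter). For compound 3 in this assay the estimate is 50 nM, within a range of 15 nM to 200 nM.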

Compound 3, half-maximal inhibitory concentration: 580 nM
The estimate for compound 3 lay 12-fold (1.06 log units) below the measured number; measured number outside the range, above it.
By their numbers in this assay, from the lowest: compound 1; then compounds 2 and 3 (each within the scatter of the next).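

In this assay the replacement of methylamino by 3-aminopropyl on a saturated chain carbon, three bonds along the chain from an aromatic carbon, gives a large step toward weaker inhibition (a 22-fold higher number from compound 1 to compound 3 (1.35 log units; beyond the scatter)). This first measured single-place step shows that this position is sensitive to the change, even though the group's counts of hydrogen-bond donors and acceptors stay the same, so those counts alone do not set the value here. Nothing at hand accounts for the size of the step.

The compounds shown leave open whether the longer chain or the unsubstituted terminal amine carries the loss, as the two arrive together in this step. A methylamino end on the longer chain, or a terminal amine on a shorter chain such as 2-aminoethyl, would pull them apart.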